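The source may hold more compounds than are shown below. What is called first, only, known or untested is meant among the compounds shown, and "the series" means these compounds.

In an ADME assay on microsomes from liver (Rattus norvegicus) for metabolic stability, read by LC-MS, using NADPH, at 37 degrees C (a higher number here means that the compound lasts longer, a lower number that the compound disappears faster), compound 1 (`Cc1ccccc1-c1nc(CN2CCC(C(=O)NCCCN3CC(C)(C)CC(C)(C)C3)CC2)c(C)o1`) gives 0.095 h. Compound 2 (`Cc1ccccc1-c1nc(CN2CCC(C(=O)NCCCN3CCCCC3)CC2)c(C)o1`) gives > 0.5 h, which is a limit of the assay and not a number. Compound 3 (`Cc1ccccc1-c1nc(CN2CCC(C(=O)NCCCN3CCCC(C(C)C)C3)CC2)c(C)o1`) has not yet been measured. It differs from compound 2 by isopropyl in place of hydrogen on a saturated ring carbon. Going by the values given here, one measured step bears on this change: an at least 5.2-fold higher number from compound 1 to compound 2 (0.72 log units; beyond the scatter), which came with the removal of carbon groups from that same ring. Compound 3 puts carbon back on the ring, so the step is read in reverse, and a shorter half-life is expected, moving towards compound 1 at 0.095 h. Isopropyl restores only part of that carbon, so the expected change is an at least 2.5-fold lower number from compound 2 to compound 3 (0.39 log units; beyond the scatter). The estimated half-life of compound 3 is 0.2 h, within an expected range of 0.08 h to 0.5 h.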

Compound 3, half-life: 0.323 h
Beside the measured number, compound 3's estimate is 1.6-fold (0.21 log units) below it; measured number inside the range.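

In this assay, replacing the larger ring group with the isopropyl-bearing ring gives a 3.4-fold higher number from compound 1 to compound 3 (0.53 log units; beyond the scatter), so carbon added to this ring need not bring the half-life down as far as the larger group does. Against the ring without isopropyl, the change gives an at least 1.5-fold lower number from compound 2 to compound 3 (0.18 log units; that floor lies within the scatter), so no real loss of half-life can be claimed for isopropyl at this position. The true size of that step stays unknown because compound 2 has a limit of the assay and not a number: the limit of > 0.5 h in this assay, at which 1 of the 3 values shown sits.

The compounds shown leave open how long compound 2 actually lasts, and so how much isopropyl costs, if anything. They also leave open whether a hydroxyl group or a fluorine atom on the same ring carbon would give a half-life different from that of compound 3.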